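Swapping Bromo for Chloro on the Benzyl Group

A few compounds are considered here, and "the series" means these few. Any claim that something is new, unique, unknown or untested is made for them only; others in the source may bear on it.

In a functional assay on DU-145 cells (Homo sapiens) for inhibition, read by trypan blue exclusion, with a stated time of 96 h (on this read-out lower numbers stand for stronger inhibition of growth and higher numbers for weaker inhibition of growth), compound 3 `CSc1ccc(/C=C(/SCc2ccc(Br)cc2)C(=O)c2ccc(C(=O)O)cc2)cc1` gives 10000 nM, the highest number among the values shown. Compound 1 `O=C(O)c1ccc(C(=O)/C(=C\c2ccc(Cl)c([N+](=O)[O-])c2)SCc2ccc(Cl)cc2)cc1` gives 1000 nM, a lower number, and the gap between the two lies beyond the scatter. Compound 2 `O=C(O)c1ccc(C(=O)/C(=C\c2ccc(Br)c([N+](=O)[O-])c2)SCc2ccc(Cl)cc2)cc1` gives < 1000 nM, which is a limit and not a number.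

Compound 4 `CSc1ccc(/C=C(/SCc2ccc(Cl)cc2)C(=O)c2ccc(C(=O)O)cc2)cc1` has not yet been measured. It differs from compound 3 by one exchange, (chloro in place of bromo on an aromatic carbon), which turns the 4-bromobenzyl group into the 4-chlorobenzyl group.

Among the measured compounds shown here, only one measured step involves these two halogens: a number no higher from compound 1 to compound 2 (the limit leaves the size open). That step runs the opposite way, with bromo in place of chloro on an aromatic carbon, and it lies outside the benzyl group. As far as these compounds go, as the limit of < 1000 nM in this assay, at which 1 of the 3 values shown sits, shows, its size stays open, so it gives only weak guidance for this exchange. The best anchor is therefore compound 3 itself, at 10000 nM in this assay.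

The expected change, a 1.3-fold lower number from compound 3 to compound 4 (0.10 log units; within the scatter), is estimated to be no larger than the scatter, with no firm direction. For compound 4 the estimated value is 8000 nM, with an expected range of 2500 nM to 25000 nM.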

Compound 4, concentration for 50% growth inhibition: > 100000 nM
Compound 4 was reported as a limit; the forecaster's own chance of this, stated with the estimate: 25%; middle value at least 12-fold (1.09 log units) away from the limit.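

On the core of compound 3, this halogen position is not interchangeable: this assay gives an at least 10-fold higher number from compound 3 to compound 4 (1.00 log units; beyond the scatter), a step whose size the earlier bromo and chloro pair could not supply. The value of compound 4, > 100000 nM, is a limit of the assay and not a number. The 4-chlorobenzyl group also sits in compound 1 and compound 2, and with that group held constant, the 4-(methylsulfanyl)phenyl group gives both an at least 100-fold higher number from compound 2 to compound 4 (2.00 log units; beyond the scatter) and an at least 100-fold higher number from compound 1 to compound 4 (2.00 log units; beyond the scatter), so the 4-chlorobenzyl group does not go with weak growth inhibition on every aryl partner shown.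

As far as these compounds go, whether the halogen exchange carries the same weight at its two sites stays undecided: the same change on two cores in this assay, a number no higher (the limit leaves the size open) from compound 1 to compound 2 and an at least 10-fold lower number (1.00 log units; beyond the scatter) from compound 4 to compound 3; the limit leaves it open whether they differ Also open is how a fluoro, methoxy or amine group on the same aromatic carbon of the benzyl ring would read, and whether the 4-bromobenzyl group would keep its edge over the 4-chlorobenzyl group when paired with the 4-chloro-3-nitrophenyl group.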